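This account rests on a few compounds, and the source may have more. Where it says the series, first, only, none or still open, it means among the compounds named here.

In a functional assay on HCT-116 cells (Homo sapiens) for cytotoxicity, read by hypoxanthine incorporation, with a stated time of 72 h, tested at 10 uM (a higher number here means more inhibition of growth at the concentration tested, a lower number less inhibition of growth), compound 3 `CC(C)C[C@@H]1NC(=O)[C@H]([C@@H](OCc2ccccc2)c2ccccc2)NC(=O)[C@@H](Cc2ccccc2)NC(=O)[C@@H](CC(C)C)NC(=O)[C@H](C(C)C)N(C)C1=O` gives 64% as the second highest of three numbers, with compound 2 `CC(C)C[C@@H]1NC(=O)[C@@H]([C@H](OCc2ccccc2)c2ccccc2)NC(=O)[C@@H](Cc2ccccc2)NC(=O)[C@@H](CC(C)C)NC(=O)[C@H](C(C)C)N(C)C1=O` at 94% above it and compound 1 `CC(C)C[C@@H]1NC(=O)[C@H](Cc2ccccc2)NC(=O)[C@H](CCCCNC(=O)OC(C)(C)C)NC(=O)[C@H](CC(C)C)NC(=O)[C@H](C(C)C)NC1=O` at 0% furthest away. Compound 4 `CC(C)C[C@@H]1NC(=O)[C@H]([C@H](OCc2ccccc2)c2ccccc2)NC(=O)[C@@H](Cc2ccccc2)NC(=O)[C@@H](CC(C)C)NC(=O)[C@H](C(C)C)N(C)C1=O` is still unmeasured. Its difference from compound 3 is the two compounds have the same atoms and bonds and differ only in configuration as drawn: 1 of 6 stereo elements differ; a stereocentre at a saturated chain carbon is drawn S in compound 3 and R in compound 4 and nothing else. Among the measured compounds shown here, one measured step bears on this, the move of a number 30 percentage points lower from compound 2 to compound 3 (beyond the scatter) in which a saturated ring carbon and a saturated chain carbon both change from R to S, and that gap stands with the fact that compounds 2 and 3 differ only in the configuration as drawn as its only basis. From the compounds shown here alone, how the gap divides between the two stereocentres is unknown. With one stereo element changing here against two in a number 30 percentage points lower from compound 2 to compound 3 (beyond the scatter) as the precedent, a smaller step is expected in this assay and upward rather than downward. An estimated a number 12 percentage points higher from compound 3 to compound 4 (beyond the scatter) is expected, within a wide margin. Compound 4 is estimated at 76% with 45% to 97% as the expected range.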

Compound 4, percent growth inhibition at one concentration: 25%
For compound 4 the middle estimate is 51 percentage points above the measured one; measured number outside the range, below it.
By their numbers in this assay, from the lowest: compound 1; then compound 4; then compound 3; then compound 2.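

In this assay the two stereocentres can now be read singly: changing only the saturated ring carbon from R to S gives a number 69 percentage points lower from compound 2 to compound 4 (beyond the scatter), and changing only the saturated chain carbon from S to R gives a number 39 percentage points lower from compound 3 to compound 4 (beyond the scatter). The earlier a number 30 percentage points lower from compound 2 to compound 3 (beyond the scatter) is therefore not the sum of two falls: the ring carbon change lowers the number, while with that carbon drawn S, the chain carbon drawn S stands higher than drawn R. Both single-centre gaps rest on configuration alone: the fact that compounds 3 and 4 differ only in the configuration as drawn

The combination of ring carbon R with chain carbon S lies outside the compounds shown, so whether the chain carbon's preference holds with the ring carbon drawn R stays open. Also open, from the compounds shown here alone, is how a free hydroxyl or an amine in place of the benzyl ether would read at this chain carbon.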